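A few compounds are considered here, and "the series" means these few. Any claim that something is new, unique, unknown or untested is made for them only; others in the source may bear on it.

In a functional assay on A2780 cells (Homo sapiens) for antiproliferative activity, read by fluorescence, with a stated time of 72 h (a lower number here means a stronger inhibitor, a higher number a weaker inhibitor), the measured compounds are:

Compound 1 `CN1CCC(C(=O)N2Cc3c(NC(=O)c4ccc5ccccc5c4)n[nH]c3C2(C)C)CC1`: 270 nM
Compound 2 `CN1CCC(C(=O)N2Cc3c(NC(=O)c4ccsc4)n[nH]c3C2(C)C)CC1`: 140 nM
Compound 3 `CN1CCC(C(=O)N2Cc3c(NC(=O)c4ccc(Cl)cc4)n[nH]c3C2(C)C)CC1`: 120 nM

Compound 3 shares the low end of this short series with compound 2, and the two cannot be told apart, given a 1.2-fold lower number from compound 2 to compound 3 (0.07 log units; within the scatter). Only compound 1 stands clearly apart from compound 3, as shown by a 2.3-fold lower number from compound 1 to compound 3 (0.35 log units; beyond the scatter).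

The next compound is compound 4 `CN1CCC(C(=O)N2Cc3c(NC(=O)c4cccs4)n[nH]c3C2(C)C)CC1`, which has thiophen-2-yl in place of 4-chlorophenyl on a carbonyl carbon. The closest evidence is compound 2, which has thiophen-3-yl at that carbonyl carbon and gives 140 nM. Its exchange for 4-chlorophenyl produced a 1.2-fold lower number from compound 2 to compound 3 (0.07 log units; within the scatter). The other steps at this carbonyl carbon are also small: a 1.9-fold lower number from compound 1 to compound 2 (0.29 log units; within the scatter) and the modest 2.3-fold lower number from compound 1 to compound 3 (0.35 log units; beyond the scatter). Going by the values given here, no measured compound carries thiophen-2-yl, so the effect of this particular thiophene attachment remains unknown.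

On this evidence, no change beyond the scatter is expected in this assay. The expected change is a 1.3-fold higher number from compound 3 to compound 4 (0.10 log units; within the scatter). Compound 4 is estimated at 150 nM, with an expected range of 70 nM to 320 nM.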

Compound 4, half-maximal inhibitory concentration: 30 nM
For compound 4 the middle estimate is 5.0-fold (0.70 log units) above the measured one; measured number outside the range, below it.
By their numbers in this assay, from the lowest: compound 4; then compounds 3, 2 and 1 (each within the scatter of the next, the first and the last beyond it).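

At this carbonyl carbon, the earlier exchanges had changed the number in this assay only slightly or modestly, whereas thiophen-2-yl gives a 4.0-fold lower number from compound 3 to compound 4 (0.60 log units; beyond the scatter) and makes compound 4 the most potent of the four, also with a 9.0-fold lower number from compound 1 to compound 4 (0.95 log units; beyond the scatter) over the series' full span. The clearest new finding is that the attachment of the thiophene matters: moving from thiophen-3-yl to thiophen-2-yl gives a 4.7-fold lower number from compound 2 to compound 4 (0.67 log units; beyond the scatter) even though the two groups have the same atoms, so the earlier near-equality of thiophen-3-yl and 4-chlorophenyl said nothing about thiophenes as a class. No measurement offered here explains why this attachment stands out.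

On these data alone, what remains open is whether the gain belongs to the sulfur-containing ring itself or would also appear with furan-2-yl or pyridin-2-yl at the same carbonyl carbon. It is also unknown whether thiophen-2-yl would tolerate a methyl group or a chlorine atom on its ring, or whether its advantage would persist with a different group elsewhere on the shared core.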